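The source may hold more compounds than are shown below. What is called first, only, known or untested is meant among the compounds shown, and "the series" means these compounds.

Measured compounds:
Compound 1, `O=C1CSC(c2ccc(Cl)cc2)N1CCN1CCCCC1`, gives 68%.
Compound 2, `COc1cccc(C2SCC(=O)N2CCN2CCCCC2)c1`, gives 66%.

In an ADME assay on Vero cells (Chlorocebus sabaeus) for cytotoxicity, read by neutral red uptake, tested at 197 ug/mL (a higher number here means a weaker effect of the compound at the concentration tested, a lower number a stronger effect), compound 1 gives 68%, and in this assay compound 2 gives 66%. The two values lie within the usual scatter of each other, so compound 1 stands at a level shared with compound 2, and nothing separates the two on these numbers alone. Among the measured compounds shown here, no step between measured compounds differing in a single place has been worked out here.

Compound 3, `O=C1CSC(c2ccc(O)cc2)N1CCN1CCCCC1`, has not yet been measured. It differs from compound 1 in one place: hydroxy in place of chloro on an aromatic carbon.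

For the measured compounds named here, with only two measured compounds, both close together, the expectation for this change is a step of no more than the scatter, if anything in the weaker direction, so the step of a number 4 percentage points higher from compound 1 to compound 3 (within the scatter) is estimated as small. For compound 3 the value expected in this assay is 72%, with a range from 55% to 90%.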

Compound 3, a percentage reported as activity, at one concentration (the size of the read-out at that concentration, not a potency): 87%
Compound 3: middle estimate off by 15 percentage points, on the low side; low and high end bracket the measured number.
By their numbers in this assay, from the lowest: compounds 2 and 1 (each within the scatter of the next); then compound 3.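

Hydroxy in place of chloro on an aromatic carbon, para to a large group, gives the first step in this series that can be read from a single change: in this assay it is a number 19 percentage points higher from compound 1 to compound 3 (beyond the scatter). The read-out at this position therefore responds to the group it carries, and the higher number means that compound 3 has a weaker effect at the concentration tested. Nothing available here bears on why the number rises with this change.

The compounds shown leave open whether an amine or a carboxylic acid at this same place would move the number as hydroxy does. They also leave open whether hydroxy would give a similar step if it replaced the methoxy group of compound 2.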